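The compounds below may be only part of what the source reports. "The series", "measured", "known", "first", "only" and "open" are said of these compounds alone.

Compound 2 `Cc1cccc(CNC(=O)CN2C(=O)/C(=C/c3ccc(-c4ccc(Cl)cc4)o3)SC2=S)c1` stands, among the two numbers in hand, beside compound 1 `O=C(CN1C(=O)/C(=C/c2ccc(-c3ccc(Cl)cc3)o2)SC1=S)Nc1nnn[nH]1`: in a functional assay on K562 cells (Homo sapiens) for cytotoxicity, read by MTT assay, with a stated time of 72 h (on this read-out lower numbers stand for stronger inhibition and higher numbers for weaker inhibition), compound 2 gives 48000 nM, and in this assay compound 1 gives 52000 nM, the two within the scatter of each other. For the measured compounds named here, the only measured step, a 1.1-fold lower number from compound 1 to compound 2 (0.03 log units; within the scatter), replaced the group on the amide-type nitrogen and left the number where it was. Compound 3 `CCCNC(=O)CN1C(=O)/C(=C/c2ccc(-c3ccc(Cl)cc3)o2)SC1=S` differs from compound 2 by ethyl in place of 3-methylphenyl on a saturated chain carbon bound to an amide-type nitrogen. That single step bears on the same end of the molecule, and because a 1.1-fold lower number from compound 1 to compound 2 (0.03 log units; within the scatter) showed no movement beyond the scatter, the group on this nitrogen appears to carry little weight for this assay. Compound 3 is therefore expected to show a 1.0-fold higher number from compound 2 to compound 3 (0.02 log units; within the scatter), nothing beyond the scatter. The estimate for compound 3 in this assay is 50000 nM, with a range from 25000 nM to 100000 nM.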

Compound 3, half-maximal inhibitory concentration: 50000 nM
For compound 3 middle estimate and measured number coincide at the digits printed, within the range that was stated.
By their numbers in this assay, from the lowest: compounds 2, 3 and 1 (each within the scatter of the next).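

In this assay, the change to ethyl in place of 3-methylphenyl, on a saturated chain carbon bound to an amide-type nitrogen, gives a 1.0-fold higher number from compound 2 to compound 3 (0.02 log units; within the scatter) and so removes the aromatic ring from this end without moving the number beyond the scatter. The earlier pair had a ring on both sides, whereas propyl carries no ring at all, and the replacement of 1H-tetrazol-5-yl by propyl gives a 1.0-fold lower number from compound 1 to compound 3 (0.02 log units; within the scatter), again within the scatter. On these three compounds, a tetrazole, a substituted benzyl and a plain propyl on this nitrogen cannot be told apart, and nothing at hand offers an explanation for that.

The compounds shown leave open whether an amine or a carboxylic acid at the end of this chain, or a much longer chain, would shift the number. They also leave open whether any change in the shared core would do so.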